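Removing One Chloro from a Dichloro Purine Analogue

This account rests on a few compounds, and the source may have more. Where it says the series, first, only, none or still open, it means among the compounds named here.

Measured compounds:
compound 1, `ClCc1ccc(Cn2cnc3c(Cl)ncnc32)cc1`: 1940 nM
compound 2, `ClCc1ccccc1Cn1cnc2c(Cl)nc(Cl)nc21`: 2040 nM

Of the compounds shown here, two have been tested in a functional assay on HOP-62 cells (Homo sapiens) for cytotoxicity, read by sulforhodamine B assay, with a stated time of 48 h; on this read-out lower numbers stand for stronger inhibition of growth and higher numbers for weaker inhibition of growth. Compound 2 stands at the higher of the two numbers, but compound 1 sits so close that the gap falls within the usual scatter, so the two cannot be placed in any order on this assay. Among the measured compounds shown here, the two structures differ in more than one place, so no single-change step between them is available to learn from.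

Compound 3 `ClCc1ccccc1Cn1cnc2c(Cl)ncnc21` has not yet been measured. Compared with compound 2 it shows one change: hydrogen in place of chloro on an aromatic carbon. Compound 1, which shares this simpler core, gives a number near that of compound 2, but because its benzyl part also differs, it does not isolate the effect of the chloro. For the measured compounds named here, with no measured pair that isolates this change, the step is expected to be small, and I expect no shift beyond the scatter in this assay, an estimated step of a 1.1-fold higher number from compound 2 to compound 3 (0.03 log units; within the scatter). For compound 3 my estimate in this assay is 2200 nM, within a range of 900 nM to 5500 nM.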

Compound 3, concentration for 50% growth inhibition: 2510 nM
Compound 3: middle estimate off by 1.1-fold (0.06 log units), on the low side; the range from low to high includes it.
By their numbers in this assay, from the lowest: compounds 1, 2 and 3 (each within the scatter of the next).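

In this assay, among the compounds shown here, the step of a 1.2-fold higher number from compound 2 to compound 3 (0.09 log units; within the scatter) is the first measured comparison that isolates a single change: hydrogen in place of chloro on an aromatic carbon, at the position between two ring nitrogen atoms. Compounds 1 and 2 could not show this, as their structures differ in more than one place. This pair shows that, with the benzyl part of compound 2 held constant, removing this chloro leaves the number within the usual scatter, so compound 2 and compound 3 cannot be placed in order, and no measurement shown offers an explanation for this result.

The compounds shown leave open whether a different group at this same position, such as an amine or a methoxy group, would move the number beyond the scatter. Also open, as far as these compounds go, is whether the same change from chloro to hydrogen would give a similar step on a compound carrying the benzyl part of compound 1.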